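A few compounds are considered here, and "the series" means these few. Any claim that something is new, unique, unknown or untested is made for them only; others in the source may bear on it.

Compound 1 `Cc1c(N(C)C)nc(CCCCCCCCCCO)c(O)c1C` was tested in a functional assay on cells (Lymphocyte, Homo sapiens) for inhibition, read by flow cytometry, using a membrane potential dye, with a stated time of 16 h, tested at 500 nM (a higher number here means a stronger effect of the compound at the concentration tested, a lower number a weaker effect), where compound 1 gives 50%. Within the data shown here, that is the lower of the two numbers measured so far: compound 2 `CCCCCCCCCCCCCCCCc1c(C)c(N2CCC2)nc(C)c1O` gives 89% in this assay, a gap beyond the usual scatter. Compound 3 `CCCCCCCCCCCCCCCCc1nc(N(C)C)c(C)c(C)c1O` has not yet been measured. It differs from compound 1 by hexyl in place of hydroxy on a saturated chain carbon, ten or more bonds along the chain from an aromatic carbon. Among the measured compounds shown here, no step between measured compounds matches this change directly, but compound 2, whose chain also ends without a hydroxy, gives 89%. An upward step a number 35 percentage points higher from compound 1 to compound 3 (beyond the scatter) is therefore expected. Compound 3 is estimated to give 85%, likely between 65% and 98%.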

Compound 3, a percentage reported as activity, at one concentration (the size of the read-out at that concentration, not a potency): 92%
Compound 3: middle estimate off by 7 percentage points, on the low side; the measured number falls inside the stated range.
By their numbers in this assay, from the lowest: compound 1; then compounds 2 and 3 (each within the scatter of the next).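

In this assay hexyl in place of hydroxy on a saturated chain carbon, ten or more bonds along the chain from an aromatic carbon, gives a number 42 percentage points higher from compound 1 to compound 3 (beyond the scatter) with the rest of the core unchanged. Among these compounds, this is the first direct reading of this change, and it shows that the read-out is sensitive to what stands this far along the chain. Among the compounds shown here, the single step swaps the hydroxy and adds chain length together, so the two cannot be separated.

On these data alone, whether a decyl chain, or an amine or a carboxylic acid on that same chain carbon, would read like compound 1 or compound 3 stays open. Nothing measured here explains the step.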